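The compounds below may be only part of what the source reports. "The series", "measured", "known", "first", "only" and "open" are said of these compounds alone.

Measured so far:
compound 1, `O=C(O)c1nn(Cc2cccc(Cl)c2)c2ccccc12`, gives 400 mg/kg in a functional assay on the whole organism (Testis, strain Long-Evans) with Rattus norvegicus as the target, with a stated time of 5 days; a lower number here means that less compound is needed, a higher number that more compound is needed for the effect;
compound 2, `O=C(O)c1nn(Cc2ccc(Cl)c(Cl)c2)c2ccccc12`, gives 448 mg/kg;
compound 3, `O=C(OCC(O)CO)c1nn(Cc2ccccc2Cl)c2ccccc12`, gives 503 mg/kg.

All three numbers lie within the usual scatter of one another, so none is set apart. From compound 1 to compound 2 the change is chloro in place of hydrogen on an aromatic carbon, and it gave a 1.1-fold higher number from compound 1 to compound 2 (0.05 log units; within the scatter). Compound 4, `O=C(OCC(O)CO)c1nn(Cc2ccc(Cl)cc2Cl)c2ccccc12`, has not yet been measured; it differs from compound 3 by chloro in place of hydrogen on an aromatic carbon. The surroundings are not identical: in compound 2 the entering chloro sits ortho to a chloro group, in compound 4 meta to a chloro group, while both sit para to a large group, so this is the same kind of change rather than the same change. How the core of compound 1 and the core of compound 3 differ is not broken down here.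

For compound 4 a small step is expected, a 1.1-fold higher number from compound 3 to compound 4 (0.03 log units; within the scatter), because the same kind of change gave a 1.1-fold higher number from compound 1 to compound 2 (0.05 log units; within the scatter). Compound 4 is therefore estimated at 540 mg/kg, with a likely range from 300 mg/kg to 950 mg/kg.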

Compound 4, minimum effective dose: 69 mg/kg
Beside the measured number, compound 4's estimate is 7.8-fold (0.89 log units) above it, and the stated range ends above it.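

In this assay, the same swap of hydrogen for chloro on an aromatic carbon gave a 7.3-fold lower number from compound 3 to compound 4 (0.86 log units; beyond the scatter), and it did not behave alike on the two cores: the same change on two cores in this assay, a 1.1-fold higher number (0.05 log units; within the scatter) from compound 1 to compound 2 and a 7.3-fold lower number (0.86 log units; beyond the scatter) from compound 3 to compound 4, 8.2-fold (0.91 log units) apart, beyond the scatter of two such steps. This change therefore cannot simply be carried from one core to another in this series, since a step seen on one core says little about its size on the other. Among these compounds, what this does not show is the reason for the gap, as the two cores differ, the entering chloro has different surroundings in each pair, and each core offers only a single pair.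

The compounds shown leave open whether a fluoro or a methyl group entering at the same place would give a step like the one from 2-chlorophenyl to 2,4-dichlorophenyl. They also leave open whether that step would survive if the ester side chain of compound 3 gave way to an amide or a longer chain.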